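This account rests on a few compounds, and the source may have more. Where it says the series, first, only, none or still open, it means among the compounds named here.

Working notes on the series. Compound 1 `CNC(=O)c1ccc(Oc2cccc(NC(=S)Nc3ccc(C)c(C)c3)c2)nc1` gives 67400 nM in a functional assay on PC-3 cells (Homo sapiens) for antiproliferative activity, read by MTT assay (on this read-out lower numbers stand for stronger inhibition and higher numbers for weaker inhibition), the highest of the two numbers in hand. Compound 2 `CNC(=O)c1ccc(Oc2cccc(NC(=S)Nc3ccc(Br)c(C(F)(F)F)c3)c2)nc1` gives 2670 nM in this assay, a markedly lower number. Compound 3 `CNC(=O)c1ccc(Oc2cccc(NC(=S)Nc3ccc(OC(F)(F)F)cc3)c2)nc1` reaches only a limit of this assay, > 100000 nM, so no number is available for it; this is the case described by the limit of > 100000 nM in this assay, at which 1 of the 3 values shown sits. Compound 4 `CNC(=O)c1ccc(Oc2cccc(NC(=S)Nc3ccc(Cl)cc3Cl)c2)nc1` is still to be measured; it differs from compound 1 by 2,4-dichlorophenyl in place of 3,4-dimethylphenyl on an amide-type nitrogen. The two measured analogues with halogen-bearing aryl groups fall on either side of compound 1, so the direction of this step cannot be read from them. A moderate downward step a 3.4-fold lower number from compound 1 to compound 4 (0.53 log units; beyond the scatter) is expected for compound 4, with a broad range; compound 4 is estimated at 20000 nM, between 3000 nM and 100000 nM.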

Compound 4, half-maximal inhibitory concentration: 19300 nM
For compound 4 the middle estimate is 1.0-fold (0.02 log units) above the measured one, and the stated range covers the measured number.
By their numbers in this assay, from the lowest: compound 2; then compound 4; then compound 1. At a limit, above all of these: compound 3.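

Replacing 3,4-dimethylphenyl with 2,4-dichlorophenyl on the amide-type nitrogen gives, in this assay, a 3.5-fold lower number from compound 1 to compound 4 (0.54 log units; beyond the scatter). Going by these compounds alone, this is the first comparison that isolates one place, and it shows that the aryl group on this nitrogen alone can shift the number beyond the scatter. Compound 3 remains a limit rather than a number: the limit of > 100000 nM in this assay, at which 1 of the 4 values shown sits.

Going by these compounds, whether the chlorine atoms or their placement carry the step remains open, since the two aryl groups differ in both. On these data alone, how a methoxy, amine or carboxylic acid group on this aryl ring would read also remains open.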